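Methoxy in place of hydrogen on compound 3

This account rests on a few compounds, and the source may have more. Where it says the series, first, only, none or still open, it means among the compounds named here.

Measured so far in a functional assay on A549 cells (Homo sapiens) for antiproliferative activity, read by MTT assay, with a stated time of 48 h (a higher number here means a weaker inhibitor, a lower number a stronger inhibitor), as follows:
- compound 1 `COc1ccc(/C=C/C(=O)Nc2nnc(-c3ccc(C)cc3)s2)cc1` gives 0.66 ug/mL
- compound 2 `O=C(/C=C/c1ccc(C(F)(F)F)cc1)Nc1nnc(-c2ccccc2)s1` gives 1.78 ug/mL
- compound 3 `O=C(/C=C/c1ccccc1)Nc1nnc(-c2ccccc2)s1` gives 1.75 ug/mL

Compound 3 stands with compound 2 at the upper end of these numbers, the two lying within the scatter of each other, and compound 1 lies clearly lower than both.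

The next entry is compound 4 `COc1ccc(/C=C/C(=O)Nc2nnc(-c3ccccc3)s2)cc1` and the change from compound 3 is methoxy in place of hydrogen on an aromatic carbon in which methoxy takes the place of hydrogen on an aromatic carbon, phenyl to 4-methoxyphenyl.

Going by the values given here, one measured step bears directly on that place. It runs a 1.0-fold lower number from compound 2 to compound 3 (0.01 log units; within the scatter) and so gives no sign of a large step from a group there. Compound 1 at 0.66 ug/mL already carries the methoxy but also differs from compound 4 by a further methyl group, so the gap from compound 3 cannot be given to methoxy alone. A modest step towards a lower number in this assay is therefore expected, and it may not clear the scatter.

The expected shift is a 1.8-fold lower number from compound 3 to compound 4 (0.24 log units; within the scatter) on this estimate. For compound 4 the estimated value is 1 ug/mL with an expected range of 0.45 ug/mL to 2 ug/mL in this series.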

Compound 4, half-maximal inhibitory concentration: 0.76 ug/mL
Compound 4: the middle estimate sits 1.3-fold (0.12 log units) above what was measured; measured number inside the range.
By their numbers in this assay, from the lowest: compounds 1 and 4 (each within the scatter of the next); then compounds 3 and 2 (each within the scatter of the next).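

In this assay, the place that gave no readable step when trifluoromethyl and hydrogen were exchanged (a 1.0-fold lower number from compound 2 to compound 3 (0.01 log units; within the scatter)) does respond to methoxy, with a 2.3-fold lower number from compound 3 to compound 4 (0.36 log units; beyond the scatter) on adding it to the unsubstituted phenyl and a 2.3-fold lower number from compound 2 to compound 4 (0.37 log units; beyond the scatter) when it takes the place of trifluoromethyl. These two steps are modest but beyond the scatter, so among the three groups seen at this place, methoxy alone separates from the others, while hydrogen and trifluoromethyl stay together. The low number of compound 1 can now be read as going with methoxy and not with its additional methyl, as removing that methyl gives only a 1.2-fold higher number from compound 1 to compound 4 (0.06 log units; within the scatter), which is within the scatter, and no measurement at hand explains why methoxy shifts the number when trifluoromethyl does not.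

Going by these compounds, with only hydrogen, trifluoromethyl and methoxy at this place, it remains open whether the step is particular to methoxy or is shared by a longer chain such as ethoxy, by a hydroxyl or by a dimethylamino group. On these data alone, it is also open whether a carboxylic acid or a chlorine atom there would stay with compound 3 or move towards compound 4.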